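The source may report more compounds than this note shows. Statements on the series, on what has been measured and on what is new or still open speak of the compounds shown alone.

Measured in a functional assay on HEK293 cells for agonist activity at G-protein coupled receptor 39 (Homo sapiens), read by scintillation proximity assay and inositol phosphate accumulation, with a stated time of 75 min; on this read-out lower numbers stand for an effect already at smaller amounts and higher numbers for an effect only at larger amounts of compound:
compound 1 `CCC(C(=O)NC1CC(=O)Nc2c1c(C)nn2-c1ncnc2nc[nH]c12)c1ccccc1`: 79 nM
compound 2 `Cc1nn(-c2ncnc3nc[nH]c23)c2c1C(OCc1ccc(Cl)cc1Cl)CC(=O)N2`: 243 nM
compound 3 `CCCCCCCCOC1CC(=O)Nc2c1c(C)nn2-c1ncnc2nc[nH]c12`: 388 nM

Among these three numbers, compound 2 stands second highest. Nearest to it lies compound 3, a 1.6-fold higher number from compound 2 to compound 3 (0.20 log units; within the scatter), while compound 1 gives a lower number by a gap beyond the scatter. Compound 4 `Cc1nn(-c2ncnc3nc[nH]c23)c2c1C(OCC(C)C)CC(=O)N2` is not yet measured. It differs from compound 2 by isopropyl in place of 2,4-dichlorophenyl on a saturated chain carbon bound to an oxygen on a saturated carbon. For the measured compounds named here, only one measured step touches this place: a 1.6-fold higher number from compound 2 to compound 3 (0.20 log units; within the scatter), in which heptyl in place of 2,4-dichlorophenyl left the number within the scatter. Since isopropyl brings only three heavy atoms where heptyl brought a longer chain, a modest rise toward higher numbers is expected for compound 4, estimated as a 2.5-fold higher number from compound 2 to compound 4 (0.39 log units; beyond the scatter). Compound 4 is therefore expected at 600 nM, with a range from 200 nM to 1800 nM.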

Compound 4, half-maximal effective concentration: 111 nM
Beside the measured number, compound 4's estimate is 5.4-fold (0.73 log units) above it; the measured number lies below the stated range.
By their numbers in this assay, from the lowest: compounds 1 and 4 (each within the scatter of the next); then compounds 2 and 3 (each within the scatter of the next).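

In this assay this position proves responsive to the group it carries: isopropyl in place of 2,4-dichlorophenyl gives a 2.2-fold lower number from compound 2 to compound 4 (0.34 log units; beyond the scatter) and isopropyl in place of heptyl gives a 3.5-fold lower number from compound 3 to compound 4 (0.54 log units; beyond the scatter) in the same direction. The earlier step, a 1.6-fold higher number from compound 2 to compound 3 (0.20 log units; within the scatter), had not shown such a response. Nothing available explains the shift. On these data alone, whether a shorter chain than isobutyl would continue this trend remains open, as does the effect of an amine or a carboxylic acid at this place.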